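This account rests on a few compounds, and the source may have more. Where it says the series, first, only, none or still open, it means among the compounds named here.

Measured so far, in an ADME assay on microsomes from liver (Rattus norvegicus) for metabolic stability, with a stated time of 10 min; on this read-out lower numbers stand for a less stable compound and higher numbers for a more stable compound:
compound 1 `CC(C)NCCS(=O)(=O)NC(=O)c1ccc(Nc2nc(NC3(c4ccc(Cl)cc4)CC3)nc(OCC(F)(F)F)n2)cc1`: 100%
compound 2 `CC(C)NC(=O)NCCS(=O)(=O)NC(=O)c1ccc(Nc2nc(NC3(c4ccc(Cl)cc4)CC3)nc(OCC(F)(F)F)n2)cc1`: 97%
compound 3 `O=C(NS(=O)(=O)C1CC1)c1ccc(Nc2nc(NC3(c4ccc(Cl)cc4)CC3)nc(OCC(F)(F)F)n2)cc1`: 85%

Compound 3 stands lowest of the three, as this assay shows; compound 2 lies nearest to it and compound 1 furthest. Compound 4 `O=C(NS(=O)(=O)CCNCc1ccccc1)c1ccc(Nc2nc(NC3(c4ccc(Cl)cc4)CC3)nc(OCC(F)(F)F)n2)cc1` differs from compound 3 in one place: 2-(benzylamino)ethyl in place of cyclopropyl on a sulfonyl sulfur. Within the data shown here, the steps that bear on this are a number 15 percentage points lower from compound 1 to compound 3 (beyond the scatter) and a number 12 percentage points lower from compound 2 to compound 3 (beyond the scatter): each time the cyclopropyl stood in for a two-carbon chain carrying a nitrogen, the number fell modestly. Compound 4 restores a chain of that kind on the same sulfur, so a modest rise is expected, a number 9 percentage points higher from compound 3 to compound 4 (within the scatter). Compound 4 is therefore estimated at 94%, within 84% to 100%.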

Compound 4, percent of the compound remaining: 100%
Estimate against measurement, compound 4: 6 percentage points below, within the range that was stated.
By their numbers in this assay, from the lowest: compound 3; then compounds 2, 1 and 4 (each within the scatter of the next).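

In this assay the step from cyclopropyl to 2-(benzylamino)ethyl on the sulfonyl sulfur gives a number 15 percentage points higher from compound 3 to compound 4 (beyond the scatter) and so shows that the higher number also holds with a six-membered aromatic ring on the chain. On the amine nitrogen, benzyl in place of isopropyl gives no change at the digits printed from compound 1 to compound 4 (within the scatter) and benzyl in place of isopropylcarbamoyl gives a number 3 percentage points higher from compound 2 to compound 4 (within the scatter) so these three groups cannot be told apart here. From the compounds shown here alone, how a longer chain or a carboxylic acid on the chain would behave stays open. Nothing here explains the rise from cyclopropyl.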